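Swapping an aryl ether for an aryl ketone on the amide arm

A few compounds are considered here, and "the series" means these few. Any claim that something is new, unique, unknown or untested is made for them only; others in the source may bear on it.

Three compounds share one core and differ only in the group on a saturated chain carbon bound to a carbonyl carbon. Compound 1 `CC(C)C[C@H](N)c1cc(C(F)(F)F)ccc1N1CCN(C(=O)COc2ccc(O)cc2)CC1` gives 4600 nM in an assay on HEK293 cells for displacement of a labelled ligand from Melanocortin receptor 4 (Homo sapiens); a higher number here means a weaker inhibitor, a lower number a stronger inhibitor. Compound 2 `CC(C)C[C@H](N)c1cc(C(F)(F)F)ccc1N1CCN(C(=O)CCC(=O)N(C)C)CC1` reaches only the limit of this assay, > 10000 nM. Compound 3 `Cc1ccc(OCC(=O)N2CCN(c3ccc(C(F)(F)F)cc3[C@@H](N)CC(C)C)CC2)c(C)c1` gives 4000 nM in this assay; its number and that of compound 1 lie within the usual scatter, as a 1.2-fold lower number from compound 1 to compound 3 (0.06 log units; within the scatter) shows, while compound 2 stands apart (an at least 2.1-fold higher number from compound 1 to compound 2 (0.33 log units; beyond the scatter) and an at least 2.5-fold lower number from compound 2 to compound 3 (0.39 log units; beyond the scatter)), a difference bounded by the limit of > 10000 nM in this assay, at which 1 of the 3 values shown sits.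

Compound 4 `CC(C)C[C@H](N)c1cc(C(F)(F)F)ccc1N1CCN(C(=O)CCC(=O)c2ccc(Cl)cc2)CC1` is not yet measured. It differs from compound 3 by ((4-chlorophenyl)carbonyl)methyl in place of 2,4-dimethylphenoxy on a saturated chain carbon bound to a carbonyl carbon. Among the measured compounds shown here, the one measured change that removed the aromatic ring, compound 1 to compound 2, cost potency; compound 4 keeps an aromatic ring but loses the ether oxygen for a ketone and gains a chlorine. Compound 4 is therefore expected to stay near compound 3, with a slight weakening possible, an expected step of a 1.4-fold higher number from compound 3 to compound 4 (0.14 log units; within the scatter). The estimated value for compound 4 is 5500 nM, within 2000 nM to 20000 nM.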

Compound 4, inhibition constant: 820 nM
Compound 4: the middle estimate sits 6.7-fold (0.83 log units) above what was measured; the measured number lies below the stated range.
By their numbers in this assay, from the lowest: compound 4; then compounds 3 and 1 (each within the scatter of the next). At a limit, above all of these: compound 2.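

Among the compounds shown here, the aryl ketone of compound 4 is the first change on this arm to lower the number beyond the scatter among compounds that keep an aromatic ring: a 4.9-fold lower number from compound 3 to compound 4 (0.69 log units; beyond the scatter) and a 5.6-fold lower number from compound 1 to compound 4 (0.75 log units; beyond the scatter). An aromatic ring alone therefore does not set the number, as compound 1, compound 3 and compound 4 all carry one, yet only compound 4 stands apart from the others. Putting 4-chlorophenyl on the carbonyl carbon in place of dimethylamino gives an at least 12-fold lower number from compound 2 to compound 4 (1.08 log units; beyond the scatter), a step that has only a lower bound, set by compound 2: the limit of > 10000 nM in this assay, at which 1 of the 4 values shown sits.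

The ketone, the longer link and the chlorine all enter together, so the gain cannot be assigned to any one of them. On these data alone, a plain phenyl ketone and a 4-chlorophenoxy group would be the direct tests, and whether a bromine or a methoxy group could stand in for the chlorine remains open.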